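Cyclohexyl-to-phenyl exchange on two acylurea and oxazoline cores

The compounds below may be only part of what the source reports. "The series", "measured", "known", "first", "only" and "open" are said of these compounds alone.

Measured so far in a functional assay on M21 cells (Homo sapiens) for inhibition, read by sulforhodamine B assay, with a stated time of 48 h; a lower number here means a stronger inhibitor of growth, a higher number a weaker inhibitor of growth:
compound 1 `c1cc(C2CCCCC2)ccc1NC1=NCCO1` gives 17800 nM;
compound 2 `c1ccc(-c2ccc(NC3=NCCO3)cc2)cc1` gives 8800 nM;
compound 3 `O=C(CCl)NC(=O)Nc1ccc(C2CCCCC2)cc1` gives 900 nM.

Compound 3 holds the lowest number of the three in this assay. The difference between the core of compound 1 and the core of compound 3 is not broken down here.

Compound 4 `O=C(CCl)NC(=O)Nc1ccc(-c2ccccc2)cc1` is not yet measured. It differs from compound 3 by phenyl in place of cyclohexyl on an aromatic carbon. Between compound 1 and compound 2 the difference is phenyl in place of cyclohexyl on an aromatic carbon; the two changes are of the same kind, and they differ only in the size of the group that stands para to the place of exchange. That earlier step gave a 2.0-fold lower number from compound 1 to compound 2 (0.31 log units; beyond the scatter) in this assay.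

A step of about that size is expected for compound 4, a 2.0-fold lower number from compound 3 to compound 4 (0.30 log units; within the scatter), resting on the earlier step of a 2.0-fold lower number from compound 1 to compound 2 (0.31 log units; beyond the scatter). Compound 4 is therefore estimated at 450 nM in this assay, between 200 nM and 1400 nM.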

Compound 4, concentration for 50% growth inhibition: 1400 nM
Compound 4: middle estimate off by 3.1-fold (0.49 log units), on the low side; the range from low to high includes it.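

In this assay the exchange of cyclohexyl for phenyl on the core of compound 3 gives a 1.6-fold higher number from compound 3 to compound 4 (0.19 log units; within the scatter) so the two groups are not separated on this core. The step seen on the core of compound 1 therefore does not carry over to the core of compound 3: the same change on two cores in this assay, a 2.0-fold lower number (0.31 log units; beyond the scatter) from compound 1 to compound 2 and a 1.6-fold higher number (0.19 log units; within the scatter) from compound 3 to compound 4, 3.1-fold (0.50 log units) apart, beyond the scatter of two such steps

Within the data shown here, this rests on one pair per core and shows only that the step differs between these two cores in this assay, not why it differs or how the exchange would behave on any other core.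

Open, going by these compounds, is whether an amine or a carboxylic acid on the same aromatic carbon would behave alike on both cores. Also open, on these data alone, is which part of the difference between the core of compound 1 and the core of compound 3 matters for the exchange.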